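The source may report more compounds than this note shows. Statements on the series, on what has been measured and on what is new or still open speak of the compounds shown alone.

Working notes on the series, read in a functional assay on ZR-75-1 cells (Homo sapiens) for inhibition, read by sulforhodamine B assay; a higher number here means a weaker inhibitor of growth, a lower number a stronger inhibitor of growth. Compound 1 `Cc1ccc2[nH]c(-c3ccc(-c4ccc(-c5ccc(N(C)C)cc5)cc4)cc3)nc2c1` gives 7200 nM, and compound 2 `COc1ccc(-c2ccc(-c3ccc(-c4nc5c(O)cccc5[nH]4)cc3)cc2)cc1` gives 8200 nM. Among the compounds with values here, these two values lie within the scatter of each other, so compound 2 cannot be separated from compound 1 on the numbers so far.

Compound 3 `CN(C)c1ccc(-c2ccc(-c3ccc(-c4nc5c(O)cccc5[nH]4)cc3)cc2)cc1` has not yet been measured. It differs from compound 2 in one place: dimethylamino in place of methoxy on an aromatic carbon. Dimethylamino stands in place of methoxy on an aromatic carbon of a six-membered aromatic ring of carbon only, para to a large group.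

Within the data shown here, no measured pair shows this change alone, so the expectation rests on indirect evidence. Compound 1 also carries dimethylamino, on a differently substituted core, and compound 1 gives 7200 nM, within the scatter of compound 2. Among the measured compounds shown here, with only two values, this is weak support. No shift beyond the scatter is expected in either direction, and the estimated step is a 1.2-fold lower number from compound 2 to compound 3 (0.07 log units; within the scatter). For compound 3 the estimate is 7000 nM, with an expected range of 2500 nM to 18000 nM.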

Compound 3, concentration for 50% growth inhibition: 4100 nM
Compound 3: middle estimate off by 1.7-fold (0.23 log units), on the high side, within the range that was stated.
By their numbers in this assay, from the lowest: compounds 3, 1 and 2 (each within the scatter of the next).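

In this assay, within the data shown here, 4-methoxyphenyl and 4-(dimethylamino)phenyl can now be compared directly on a shared core: a 2.0-fold lower number from compound 2 to compound 3 (0.30 log units; within the scatter) is the first direct reading of dimethylamino in place of methoxy on this aromatic carbon, para to a large group, and it does not separate the two groups at this place. A second single change, 4-hydroxy-1H-benzimidazol-2-yl in place of 5-methyl-1H-benzimidazol-2-yl with the dimethylamino kept, gives a 1.8-fold lower number from compound 1 to compound 3 (0.24 log units; within the scatter), so this change on the other part of the structure does not separate its two compounds either. Nothing measured on these compounds accounts for the numbers, and these two pairs alone give no basis for a trend at either place.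

The compounds shown leave open whether a primary amine or a carboxylic acid on this same aromatic carbon would give a step beyond the scatter, or whether a longer chain such as ethoxy would stay within it. They also leave open whether a benzimidazole carrying neither hydroxy nor methyl would read any differently, since all three compounds sit close together in this assay and define no clear direction.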